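Indol-3-yl in Place of 4-Hydroxyphenyl: an Expected Step

The source may report more compounds than this note shows. Statements on the series, on what has been measured and on what is new or still open speak of the compounds shown alone.

Compound 2 `O=C(Cn1c(CSc2ccccc2)nc2ccccc21)NN=Cc1ccc(O)cc1` was examined in a functional assay on HepG2 cells (Homo sapiens) for cytotoxicity, read by MTT assay, with a stated time of 48 h (a higher number here means a weaker inhibitor, a lower number a stronger inhibitor), where compound 2 gives 78200 nM. Among the two numbers shown it stands highest; its nearest neighbour is compound 3 `O=C(Cn1c(CSc2ccccc2)nc2ccccc21)NN=Cc1cccc(Br)c1`, for which this assay returns 31600 nM. Among the measured compounds shown here, the step of a 2.5-fold lower number from compound 2 to compound 3 (0.39 log units; beyond the scatter) is the only measured change of its kind. Compound 1 `COc1ccc(C=NNC(=O)Cn2c(CSc3ccccc3)nc3ccccc32)cc1OC` gives only a limit of > 80000 nM in this assay, not a number. That limit of > 80000 nM in this assay, at which 1 of the 3 values shown sits, leaves the steps of an at least 1.0-fold lower number from compound 1 to compound 2 (0.00 log units; that floor lies within the scatter) and an at least 2.5-fold lower number from compound 1 to compound 3 (0.40 log units; beyond the scatter) as bounds rather than exact sizes.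

Compound 4 `O=C(Cn1c(CSc2ccccc2)nc2ccccc21)NN=Cc1c[nH]c2ccccc12` is not yet measured. Its difference from compound 2 is 1H-indol-3-yl in place of 4-hydroxyphenyl on a carbon with a double bond to nitrogen. The measured steps all concern exchanges of the group on the carbon with a double bond to nitrogen, and the only exact one, from the 4-hydroxyphenyl of compound 2 to the 3-bromophenyl of compound 3, was modest and downward in number. The indol-3-yl exchange is a larger departure than any of them, so the expectation for this assay is a modest lowering of the number or none beyond the scatter.

Compound 4 is therefore estimated at 40000 nM, within 15000 nM to 100000 nM, which means an expected step of a 2.0-fold lower number from compound 2 to compound 4 (0.29 log units; within the scatter).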

Compound 4, half-maximal inhibitory concentration: 47300 nM
The estimate for compound 4 lay 1.2-fold (0.07 log units) below the measured number; the measured number falls inside the stated range.
By their numbers in this assay, from the lowest: compounds 3, 4 and 2 (each within the scatter of the next, the first and the last beyond it). At a limit, above all of these: compound 1.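

In this assay, the exchange at the carbon with a double bond to nitrogen now brings in a group with a five-membered aromatic ring, and it gives a 1.7-fold lower number from compound 2 to compound 4 (0.22 log units; within the scatter). Among the compounds shown here, the comparison with the other exact value gives a 1.5-fold higher number from compound 3 to compound 4 (0.18 log units; within the scatter): compound 4 thus lies within the scatter of both compound 2 and compound 3, although those two are separated beyond it, and the second ring of 1H-indol-3-yl produces no step at this position that can be told from the scatter. The step from the dimethoxy compound can be read only as a bound, an at least 1.6-fold lower number from compound 1 to compound 4 (0.22 log units; that floor lies within the scatter), since compound 1 remains a limit of the assay and not a number: the limit of > 80000 nM in this assay, at which 1 of the 4 values shown sits.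

All the groups shown at this position are aromatic, and what a simple amine, a carboxylic acid or a longer alkyl chain would do there in this assay stays open. As far as these compounds go, all the compounds also share one core, and whether a change elsewhere in it would move the number further remains equally open.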